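The source may report more compounds than this note shows. Statements on the series, on what has been measured and on what is new or still open speak of the compounds shown alone.

Among the measured compounds shown here, compound 1 `CCN(CC)S(=O)(=O)c1ccc(S(=O)(=O)N2CCC[C@@H](C(=O)N3CCC(C(F)(F)F)CC3)C2)cc1` is the weaker of the two measured members. In a functional assay on MIA PaCa-2 cells (Homo sapiens) for inhibition, read by MTT assay, with a stated time of 3 days (a lower number here means a stronger inhibitor, a higher number a weaker inhibitor), compound 1 gives 110 nM, the highest of the two numbers. For the measured compounds named here, compound 2 `CC(C)S(=O)(=O)c1ccc(S(=O)(=O)N2CCC[C@@H](C(=O)N3CCC(F)(F)CC3)C2)cc1` gives 9.1 nM in this assay, a lower number beyond the scatter; compound 2 differs from compound 1 in more than one place, so no single step is counted between them, and only the two values themselves are known.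

Compound 3 `CCN(CC)S(=O)(=O)c1ccc(S(=O)(=O)N2CCC[C@@H](C(=O)N3CC[C@H](OC)C3)C2)cc1` has not yet been measured. It differs from compound 1 in one place: 3-methoxypyrrolidin-1-yl in place of 4-(trifluoromethyl)piperidin-1-yl on a carbonyl carbon. Going by the values given here, no measured pair isolates this change, so there is nothing to set its size against. The step from compound 1 to compound 3 is expected to be small, at most a modest rise in number, a 1.4-fold higher number from compound 1 to compound 3 (0.13 log units; within the scatter). Compound 3 is estimated at 150 nM in this assay, with a range from 40 nM to 550 nM.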

Compound 3, half-maximal inhibitory concentration: 460 nM
For compound 3 the middle estimate is 3.1-fold (0.49 log units) below the measured one; measured number inside the range.
By their numbers in this assay, from the lowest: compound 2; then compound 1; then compound 3.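

Among the compounds shown here, on a carbonyl carbon of the compound 1 scaffold, this position is not indifferent to the group it carries: in this assay, 3-methoxypyrrolidin-1-yl in place of 4-(trifluoromethyl)piperidin-1-yl gives a 4.2-fold higher number from compound 1 to compound 3 (0.62 log units; beyond the scatter), the first single-place step and a weakening. The change alters the ring and its substituent together, from a six-membered ring bearing trifluoromethyl to a five-membered ring bearing methoxy, so this one step cannot assign the rise to either feature. No measurement on hand explains the step.

The compounds shown leave open whether ring size or substituent drives the rise; 4-methoxypiperidin-1-yl or unsubstituted pyrrolidin-1-yl on the same carbonyl carbon would help separate them. As far as these compounds go, the role of the defined stereocentre in 3-methoxypyrrolidin-1-yl also remains open.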